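Halogen Exchange Tests a Short Series in Guinea Pig Tissue

This account rests on a few compounds, and the source may have more. Where it says the series, first, only, none or still open, it means among the compounds named here.

Compound 1 `COC(=O)C1=C(C)N=C(C)/C(=C(\O)OC)C1c1cccc(C)c1` and compound 2 `COC(=O)C1=C(C)N=C(C)/C(=C(\O)OC)C1c1ccc(F)cc1` share one core and differ only in the aromatic group on a saturated ring carbon. In a functional assay (muscle tissue) with Cavia porcellus as the target (a lower number here means that less compound is needed, a higher number that more compound is needed for the effect), compound 1 gives 110 nM, and in this assay compound 2 gives 129 nM. The step of a 1.2-fold higher number from compound 1 to compound 2 (0.07 log units; within the scatter) leaves the pair indistinguishable, so compound 2 holds the nominally higher of the two numbers only within the scatter. Compound 3 `COC(=O)C1=C(C)N=C(C)/C(=C(\O)OC)C1c1ccc(Br)cc1` is the next member: bromo in place of fluoro on an aromatic carbon. Going by the values given here, the single measured step, a 1.2-fold higher number from compound 1 to compound 2 (0.07 log units; within the scatter), exchanged one aromatic group for another and did not move the number beyond the scatter; it offers no direct guide to a halogen exchange on that ring, and no other measured pair bears on it. Among the compounds with values here, with no step pointing in either direction, the expectation is that the exchange changes little, and a 1.2-fold lower number from compound 2 to compound 3 (0.07 log units; within the scatter) is estimated to remain within the scatter. Compound 3 is therefore expected to give about 110 nM in this assay, with a range from 50 nM to 260 nM.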

Compound 3, half-maximal effective concentration: 540 nM
For compound 3 the middle estimate is 4.9-fold (0.69 log units) below the measured one; the measured number lies above the stated range.
By their numbers in this assay, from the lowest: compounds 1 and 2 (each within the scatter of the next); then compound 3.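

Going by these compounds alone, the exchange of fluoro for bromo on an aromatic carbon, para to a large group, is not neutral in this assay: it gives a 4.2-fold higher number from compound 2 to compound 3 (0.62 log units; beyond the scatter), the first step in this short series to lie beyond the scatter. The earlier step from 3-methylphenyl to 4-fluorophenyl left the number within the scatter, whereas the step to 4-bromophenyl gives a 4.9-fold higher number from compound 1 to compound 3 (0.69 log units; beyond the scatter), so the choice of aromatic group on the saturated ring carbon can change how much compound is needed, and here the halogen itself makes that difference. The compounds shown offer no independent measurement that would account for this rise.

On these data alone, with only fluoro and bromo at this place, it remains open whether a chloro or iodo group would give a number close to that of compound 2 or to that of compound 3, and whether a non-halogen group such as methoxy or an amine would behave like either. As far as these compounds go, it is also open whether the same exchange would give a step of similar size on the 3-methylphenyl ring of compound 1 or with other ester groups on the shared core.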